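Acetamide to propanamide on the aldosterone synthase series

The source may report more compounds than this note shows. Statements on the series, on what has been measured and on what is new or still open speak of the compounds shown alone.

Measured so far:
compound 1 `CC[C@H]1c2cc(Cl)ccc2C(=O)N1c1cncc2c1CCC[C@H]2NC(C)=O` 97 nM
compound 2 `CC(=O)NCc1cncc(N2C(=O)c3ccc(Cl)cc3C2(C)C)c1` 59 nM

In an assay on cells for inhibition of cytochrome P450 11B2, mitochondrial (Homo sapiens), read by HTRF (a higher number here means a weaker inhibitor, a lower number a stronger inhibitor), compound 2 gives 59 nM and compound 1 gives 97 nM; the two values lie within the scatter of each other, so neither can be called the stronger inhibitor. Compound 3 `CCC(=O)NCc1cncc(N2C(=O)c3ccc(Cl)cc3C2(C)C)c1` is not yet measured. It differs from compound 2 by methyl in place of hydrogen on a saturated chain carbon bound to a carbonyl carbon, a methyl in place of hydrogen. Among the measured compounds shown here, no measured pair shows this change, so no step size is known. Compound 3 is expected to stay close to compound 2, with a 1.0-fold higher number from compound 2 to compound 3 (0.01 log units; within the scatter) not beyond the scatter, giving an estimate of 60 nM (range 25 nM to 150 nM).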

Compound 3, half-maximal inhibitory concentration: 282 nM
Compound 3: middle estimate off by 4.7-fold (0.67 log units), on the low side; the whole stated range lies below it.
By their numbers in this assay, from the lowest: compounds 2 and 1 (each within the scatter of the next); then compound 3.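

In this assay the change from acetamido to propanoylamino gives a 4.8-fold higher number from compound 2 to compound 3 (0.68 log units; beyond the scatter) and so shows that even one added methyl on this saturated chain carbon bound to a carbonyl carbon weakens inhibition beyond the scatter. Among the compounds shown here, this is the first single-place step, and it sets the acyl chain of compound 2 as a place sensitive to small additions. Nothing available accounts for the loss.

Open, going by these compounds, is whether a longer chain such as butanoyl weakens inhibition further, or whether an amine or hydroxyl on this carbon behaves as methyl does. Also open, on these data alone, is whether the same change on the core of compound 1 gives a similar step.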